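Series notes: tert-butoxycarbonyl on the ring amine nitrogen

The compounds below may be only part of what the source reports. "The series", "measured", "known", "first", "only" and "open" are said of these compounds alone.

Three compounds have numbers in an ADME assay on MCF7-DOX cells (Homo sapiens) for cytotoxicity, read by MTT assay, with a stated time of 48 h; a lower number here means a stronger inhibitor, a higher number a weaker inhibitor. Compound 1 `COc1cc(OC)c(C(=O)/C=C/c2cc(OC)c(OC)c(OC)c2)c(O)c1CC=C(C)C` gives 74900 nM. Compound 2 `COc1cc(O)c(C(=O)/C=C/c2ccc(N3CCNCC3)cc2)c(OC)c1` gives 67500 nM. Compound 3 `COc1cc(OC)c(C(=O)/C=C/c2ccc(N3CCNCC3)cc2)c(O)c1CC=C(C)C` gives 57800 nM. Compound 2 stands second highest of the three; its nearest neighbour is compound 1 and its furthest is compound 3, both within the scatter, so no order among the three numbers is claimed.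

For the measured compounds named here, the only single-place step measured is a 1.2-fold lower number from compound 2 to compound 3 (0.07 log units; within the scatter), which puts 3-methylbut-2-en-1-yl on an aromatic carbon without moving the number beyond the scatter.

Compound 4 `COc1cc(O)c(C(=O)/C=C/c2ccc(N3CCN(C(=O)OC(C)(C)C)CC3)cc2)c(OC)c1` is the unmeasured member. It differs from compound 2 as follows: tert-butoxycarbonyl in place of hydrogen on an amine nitrogen in a ring. Going by the values given here, no measured step touches the amine nitrogen in the ring, so the one step available bears on it only loosely, as an example that adding a group to the shared core left the number where it was. On that basis the step expected is a 1.0-fold lower number from compound 2 to compound 4 (0.02 log units; within the scatter), none beyond the scatter. The number expected for compound 4 is therefore 65000 nM, with a range of 30000 nM to 140000 nM.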

Compound 4, half-maximal inhibitory concentration: 47300 nM
The estimate for compound 4 lay 1.4-fold (0.14 log units) above the measured number; low and high end bracket the measured number.
By their numbers in this assay, from the lowest: compounds 4, 3, 2 and 1 (each within the scatter of the next).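

In this assay the amine nitrogen in the ring now has a measured step of its own: a 1.4-fold lower number from compound 2 to compound 4 (0.15 log units; within the scatter). Until now the only single-place step lay on an aromatic carbon, so this result extends the picture to a second site: tert-butoxycarbonyl, with 7 heavy atoms and 0 hydrogen-bond donors, replaces the hydrogen on this nitrogen without a change beyond the scatter, which also means that the free amine hydrogen is not shown to matter in this assay. Nothing available explains this outcome or ties it to any property of the group.

The compounds shown leave open whether a methyl or acetyl group on the same nitrogen, or a longer chain ending in a carboxylic acid or a primary amine, would also stay within the scatter or would produce the first step beyond it. They also leave open whether tert-butoxycarbonyl on this nitrogen and 3-methylbut-2-en-1-yl on the aromatic carbon, taken together on the shared core, would give a step beyond the scatter when each alone gives none.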